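The source may hold more compounds than are shown below. What is called first, only, known or untested is meant among the compounds shown, and "the series" means these compounds.

In a functional assay on SW-620 cells (Homo sapiens) for inhibition, read by sulforhodamine B assay, with a stated time of 48 h, tested at 0.01 uM (a lower number here means a stronger effect, a higher number a weaker effect of the compound at the concentration tested), compound 1 `O=C(Nc1cccc(-n2cc(-c3ccncc3)c(-c3cc(O)cc(Cl)c3)n2)c1)Nc1ccc(Cl)c(Cl)c1` gives 96%. Compound 2 `COc1cc(Cl)cc(-c2nn(-c3cccc(NC(=O)Nc4cc(C(F)(F)F)cc(C(F)(F)F)c4)c3)cc2-c2ccncc2)c1` gives 98% in this assay. Of these two numbers compound 1 stands at the lower end, but the gap to compound 2 lies within the scatter of repeated runs, so the two values show no real separation between them.

Compound 3 `COc1cc(Cl)cc(-c2nn(-c3cccc(NC(=O)Nc4ccc(Cl)c(Cl)c4)c3)cc2-c2ccncc2)c1` has not yet been measured in this assay. It differs from compound 1 in one place: methyl in place of hydrogen on an oxygen on an aromatic ring.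

Within the data shown here, no measured pair in this set differs by this change alone, so the size of the step can only be anticipated. Both measured compounds sit close to the top of the read-out, and compound 2 already carries the methoxy group and gives 98%. On that basis the step from compound 1 to compound 3 is expected to be a number 1 percentage points higher from compound 1 to compound 3 (within the scatter), with no direction that goes beyond the scatter. For compound 3 the estimated value in this assay is 97%, with a range from 90% to 100%.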

Compound 3, a percentage reported as activity, at one concentration (the size of the read-out at that concentration, not a potency): 100%
For compound 3 the middle estimate is 3 percentage points below the measured one; the range from low to high includes it.
By their numbers in this assay, from the lowest: compounds 1, 2 and 3 (each within the scatter of the next).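

In this assay, among these compounds, the change from hydroxy to methoxy gives a number 4 percentage points higher from compound 1 to compound 3 (within the scatter), and this is the first direct reading of this change at this position, since the earlier comparison between compound 1 and compound 2 offered no pair differing by this change alone. With compound 1 at 96% and compound 3 at 100%, the read-out at this single concentration does not separate a hydrogen from a methyl on this oxygen, so the free hydroxy shows no measurable importance under these conditions, though both numbers lie near the top of the read-out, where little effect is seen. No accompanying measurement bears on this result, and it offers no explanation for it.

From the compounds shown here alone, what remains open is whether this position would respond to a larger change, such as an amine in place of the hydroxy, or a longer chain such as propoxy in place of the methoxy. Going by these compounds, it is also open whether compound 1 and compound 3 would stay together at a concentration where the read-out falls well away from the top.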